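Series notes: methylsulfonyl in place of the smaller group

A few compounds are considered here, and "the series" means these few. Any claim that something is new, unique, unknown or untested is made for them only; others in the source may bear on it.

Compound 1 `Cn1c(-c2cccs2)nnc1[S+](C)[O-]` and compound 2 `Cn1c(-c2cccs2)nnc1S(C)(=O)=O` share one core; compound 3 `Cn1c(-c2cccc3ccccc23)nnc1[S+](C)[O-]` and compound 4 `Cn1c(-c2cccc3ccccc23)nnc1S(C)(=O)=O` share another. The difference between the two cores is not broken down here. All values come from a functional assay on the whole organism for antagonist activity, with Mus musculus as the target; a lower number here means that less compound is needed, a higher number that more compound is needed for the effect. In this assay compound 1 reaches only a limit of the assay, > 200 mg/kg. In this assay compound 2 likewise reaches only a limit, > 200 mg/kg. In this assay compound 3 also reaches only a limit, > 200 mg/kg.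

The change from compound 1 to compound 2 is a group of 4 heavy atoms (1 carbon, 2 oxygen, 1 sulfur; no ring) in place of a group of 3 heavy atoms (1 carbon, 1 oxygen, 1 sulfur; no ring), on an aromatic carbon. Its size in this assay, a step that the two limits leave unreadable from compound 1 to compound 2, cannot be read because of the limit of > 200 mg/kg in this assay, at which 3 of the 3 values shown sit.

The change from compound 3 to compound 4 is a group of 4 heavy atoms (1 carbon, 2 oxygen, 1 sulfur; no ring) in place of a group of 3 heavy atoms (1 carbon, 1 oxygen, 1 sulfur; no ring), on an aromatic carbon. It is the same kind of change, though it sits on a different core in the second pair.

Among the compounds with values here, with every measured value of the series sitting at the limit, no measured step can be carried over to the second pair. The step from compound 3 to compound 4 is expected to be about a step that the limit leaves unreadable from compound 3 to compound 4, an expectation that rests only on the absence of any readable step in this assay. For compound 4 the expected value in this assay is 300 mg/kg, with a range from 100 mg/kg to 1000 mg/kg, and a limit rather than a number is the most likely report.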

Compound 4, dose for half-maximal effect: > 200 mg/kg
Compound 4: only a limit was reported; the forecaster's own chance of this, stated with the estimate: 85%; the middle value is on the limit's open side.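

In this assay compound 4 gives > 200 mg/kg, which is a limit of the assay and not a number. As a result, no step can be read from compound 3 to compound 4: the limit of > 200 mg/kg in this assay, at which 4 of the 4 values shown sit.

The compounds shown leave open whether methylsulfonyl in place of the smaller group changes the dose needed on either core, and what dose any of the four compounds would require.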